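Working notes: replacing the aryl group of compound 3

This account rests on a few compounds, and the source may have more. Where it says the series, first, only, none or still open, it means among the compounds named here.

In a functional assay on A549 cells (Homo sapiens) for inhibition, read by CCK-8 assay, with a stated time of 48 h (on this read-out lower numbers stand for stronger inhibition and higher numbers for weaker inhibition), compound 1 (`COc1cc(-c2ccnc3cc(-c4cn(CO)c5ccccc45)nn23)cc(OC)c1OC`) gives 167 nM and compound 3 (`COc1cc(-c2ccnc3cc(-c4ccc(C)c(C)c4)nn23)cc(OC)c1OC`) gives 272 nM on the same read-out. These two numbers lie within the scatter of each other, so compound 3 stands level with compound 1 on the numbers shown. Compound 2 (`COc1cc(-c2cc3nccc(-c4c[nH]c5ccccc45)n3n2)cc(OC)c1OC`) returns > 10000 nM as a limit of the assay and not as a number.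

Compound 4 (`COc1cc(-c2ccnc3cc(-c4ccc(C(F)(F)F)cc4)nn23)cc(OC)c1OC`) keeps the core of compound 3 and differs at one place (4-(trifluoromethyl)phenyl in place of 3,4-dimethylphenyl on an aromatic carbon), with 4-(trifluoromethyl)phenyl in place of 3,4-dimethylphenyl on an aromatic carbon of the five-membered aromatic ring. For the measured compounds named here, no step between measured compounds that differ in one place is available, so the expectation rests on thin ground. Compound 3 at 272 nM and compound 1 at 167 nM carry different groups on that carbon and stay within the scatter of each other, so a collapse of activity is not expected for this change. In this assay a modest weakening is expected, estimated as a 2.2-fold higher number from compound 3 to compound 4 (0.34 log units; beyond the scatter) with wide uncertainty. For compound 4 the estimate is 600 nM with an expected range from 150 nM to 2800 nM on this read-out.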

Compound 4, half-maximal inhibitory concentration: 2070 nM
Compound 4: middle estimate off by 3.5-fold (0.54 log units), on the low side, within the range that was stated.
By their numbers in this assay, from the lowest: compounds 1 and 3 (each within the scatter of the next); then compound 4. At a limit, above all of these: compound 2.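

In this assay, exchanging 3,4-dimethylphenyl for 4-(trifluoromethyl)phenyl on the aromatic carbon of the five-membered aromatic ring gives a 7.6-fold higher number from compound 3 to compound 4 (0.88 log units; beyond the scatter). For the compounds shown here, this is the first reading of a single change at this position, and it shows that activity depends on which aryl group the carbon carries, while compound 4 at 2070 nM still returns a number and not a limit of the assay, so this exchange weakens inhibition without abolishing it. Nothing available here accounts for the size of this step.

From the compounds shown here alone, a single step does not separate the two parts of this exchange, the loss of one methyl group and the replacement of the other by trifluoromethyl, so it remains open which of them carries the weakening. Also open, going by these compounds, is how this carbon responds to other groups, such as 4-methylphenyl, 4-methoxyphenyl or a phenyl ring bearing an amine or a carboxylic acid.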